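The compounds below may be only part of what the source reports. "The series", "measured", "known", "first", "only" and "open" are said of these compounds alone.

In a functional assay (aorta) for inhibition, with Rattus norvegicus as the target (on this read-out higher numbers stand for weaker inhibition and lower numbers for stronger inhibition), compound 3 (`C/N=C(\S)[C@]1(c2ccc(Cl)cc2)CCCC[S+]1[O-]`) gives 2800 nM, within the scatter of compound 1 (`C/N=C(\S)[C@]1(c2cccc(C#N)c2)CCCC[S+]1[O-]`) at 1600 nM, and a lower number than compound 2 (`C/N=C(\S)[C@]1(c2cccc(F)c2)CCCC[S+]1[O-]`) at 7000 nM. Compound 4 (`C/N=C(\S)[C@]1(c2ccccc2)CCCC[S+]1[O-]`) differs from compound 3 by hydrogen in place of chloro on an aromatic carbon. Going by the values given here, no measured step replaces a group with hydrogen. Among the compounds with values here, the only guide is a 4.4-fold higher number from compound 1 to compound 2 (0.64 log units; beyond the scatter), a modest step with fluoro in place of cyano on an aromatic carbon. On that thin support, a modest step to a higher number in this assay is expected. The estimate for compound 4 is 5000 nM, with a range of 2200 nM to 11000 nM. The expected step is a 1.8-fold higher number from compound 3 to compound 4 (0.25 log units; within the scatter).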

Compound 4, concentration for 90% inhibition: 9500 nM
For compound 4 the middle estimate is 1.9-fold (0.28 log units) below the measured one, and the stated range covers the measured number.
By their numbers in this assay, from the lowest: compounds 1 and 3 (each within the scatter of the next); then compounds 2 and 4 (each within the scatter of the next).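

In this assay hydrogen in place of chloro gives a 3.4-fold higher number from compound 3 to compound 4 (0.53 log units; beyond the scatter) and hydrogen in place of cyano gives a 5.9-fold higher number from compound 1 to compound 4 (0.77 log units; beyond the scatter) so compounds carrying either group read stronger than the compound with hydrogen. Hydrogen in place of fluoro gives a 1.4-fold higher number from compound 2 to compound 4 (0.13 log units; within the scatter) and so leaves fluoro not separated from hydrogen on this read-out. From the compounds shown here alone, whether an amine, a carboxylic acid or a methoxy group would side with chloro and cyano or with fluoro stays open, as does the effect of moving any one group around the ring. Nothing available accounts for these steps.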